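The compounds below may be only part of what the source reports. "The series", "measured", "known", "first", "only" and "open" are said of these compounds alone.

For the measured compounds named here, in a functional assay on PC-3 cells (Homo sapiens), read by MTT assay, with a stated time of 48 h (on this read-out lower numbers stand for stronger inhibition and higher numbers for weaker inhibition), compound 2 `CCOC(=O)CN(C)C(=O)c1ccc(C(CC)(CC)c2ccc(OCC(O)C(C)(C)C)c(C)c2)n1CC` gives 25500 nM, the higher of the two numbers so far and beyond the scatter from compound 1 `CCn1c(C(=O)NCCCN(C)C)ccc1C(CC)(CC)c1ccc(OCC(=O)C(C)(C)C)c(C)c1`, which gives 1600 nM. Compound 3 `CCn1c(C(=O)NCCN(C)C)ccc1C(CC)(CC)c1ccc(OCC(O)C(C)(C)C)c(C)c1` differs from compound 2 in one place: (2-(dimethylamino)ethyl)amino in place of ((ethoxycarbonyl)methyl)(methyl)amino on a carbonyl carbon, with (2-(dimethylamino)ethyl)amino in place of ((ethoxycarbonyl)methyl)(methyl)amino on a carbonyl carbon. Compound 1 also carries a dimethylamino group and stands at 1600 nM, so a fall in the number, beyond the scatter, is expected in this assay. The expected size is an estimated 8.5-fold lower number from compound 2 to compound 3 (0.93 log units; beyond the scatter). For compound 3 the estimated value is 3000 nM, with an expected range of 800 nM to 12000 nM.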

Compound 3, half-maximal inhibitory concentration: 1630 nM
The estimate for compound 3 lay 1.8-fold (0.26 log units) above the measured number; the measured number falls inside the stated range.
By their numbers in this assay, from the lowest: compounds 1 and 3 (each within the scatter of the next); then compound 2.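

In this assay, (2-(dimethylamino)ethyl)amino in place of ((ethoxycarbonyl)methyl)(methyl)amino on a carbonyl carbon brings a 16-fold lower number from compound 2 to compound 3 (1.19 log units; beyond the scatter). For the compounds shown here, this is the first step that differs in one place, and it shows that the group on this carbonyl carbon can alone move the number beyond the scatter. Nothing available explains the size of this step.

The change swaps a whole group, so it leaves open which part of it carries the step. A carboxylic acid in the side chain, or a piperidine ring at the end of the chain, remains to be read at this position.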